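The source may report more compounds than this note shows. Statements on the series, on what has been measured and on what is new or still open speak of the compounds shown alone.

Measured so far in an assay for inhibition of histone deacetylase 4 (Homo sapiens); a lower number here means a stronger inhibitor, a higher number a weaker inhibitor:
compound 1 `O=C(c1ccc(-c2nc(-c3ccccn3)no2)s1)C(F)(F)F` gives 90 nM
compound 2 `O=C(c1ccc(-c2ncc(-c3ccccc3)s2)s1)C(F)(F)F` gives 1500 nM
compound 3 `O=C(c1ccc(-c2nc(-c3cccnc3)no2)s1)C(F)(F)F` gives 70 nM

Compound 3 carries the lowest of the three numbers. Among the measured compounds shown here, compound 1 lies nearest, and the single step between them, a 1.3-fold lower number from compound 1 to compound 3 (0.11 log units; within the scatter), is within the scatter, so compounds 1 and 3 cannot be separated on these data. For the measured compounds named here, compound 2 differs from compound 3 in more than one place, so no single step links them; its number stands well above that of compound 3, beyond the scatter.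

Compound 4 `O=C(c1ccc(-c2nc(-c3cccs3)no2)s1)C(F)(F)F` is not yet measured. Against compound 3 the change is thiophen-2-yl in place of pyridin-3-yl on an aromatic carbon. Going by the values given here, no measured step bears directly on this exchange. Among the compounds with values here, the only single step in the set, pyridin-2-yl to pyridin-3-yl, stayed within the scatter, but that exchange kept a six-membered ring and says little about a thiophen-2-yl replacement. The expected step of a 1.6-fold higher number from compound 3 to compound 4 (0.20 log units; within the scatter) is therefore none beyond the scatter, with wide uncertainty. Compound 4 is estimated at 110 nM in this assay, range 40 nM to 320 nM.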

Compound 4, half-maximal inhibitory concentration: 95 nM
Compound 4: the middle estimate sits 1.2-fold (0.06 log units) above what was measured; low and high end bracket the measured number.
By their numbers in this assay, from the lowest: compounds 3, 1 and 4 (each within the scatter of the next); then compound 2.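

Notes on the aromatic carbon of the five-membered aromatic ring with 2 nitrogen and 1 oxygen: the earlier pyridin-2-yl to pyridin-3-yl exchange kept a six-membered aromatic ring, whereas thiophen-2-yl brings a five-membered aromatic ring with sulfur as its hetero atom. In this assay this larger change still gives no separable difference, with a 1.4-fold higher number from compound 3 to compound 4 (0.13 log units; within the scatter) and a 1.1-fold higher number from compound 1 to compound 4 (0.02 log units; within the scatter), so among compound 1, compound 3 and compound 4 neither a six-membered ring nor a ring nitrogen at this carbon is required to keep the number in this range. No supporting data bear on why these three aromatic groups cannot be told apart.

As far as these compounds go, all three groups are aromatic rings attached directly at this carbon, so it remains open how this assay responds to a saturated amine such as piperidine, a carboxylic acid or a longer alkyl chain there. Substituted forms of thiophen-2-yl also remain open.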